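Benzyl Group Changes on a Shared Core: Cytotoxicity Limits

The source may report more compounds than this note shows. Statements on the series, on what has been measured and on what is new or still open speak of the compounds shown alone.

Compound 1 `CCOC(=O)c1cnc(N2CCN(Cc3ccccc3C#N)CC2)nc1Oc1c(C)cc(-c2ccc(C#N)cc2)cc1C` gives > 125000 nM in an ADME assay on MT4 cells (Homo sapiens) for cytotoxicity, read by MTT assay, with a stated time of 4 days (on this read-out higher numbers stand for lower toxicity in this test and lower numbers for higher toxicity in this test), a limit of the assay.
Compound 2 `CCOC(=O)c1cnc(N2CCN(Cc3ccc(F)cc3)CC2)nc1Oc1c(C)cc(-c2ccc(C#N)cc2)cc1C` gives > 117000 nM in this assay, a limit.
Compound 3 `CCOC(=O)c1cnc(N2CCN(Cc3ccccc3F)CC2)nc1Oc1c(C)cc(-c2ccc(C#N)cc2)cc1C` gives > 125000 nM in this assay, a limit.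

Compound 3 thus stands only at a limit, as do the other two compounds: two of the three values sit at the limit of > 125000 nM in this assay, at which 2 of the 3 values shown sit, and one at the limit of > 117000 nM in this assay, at which 1 of the 3 values shown sits. Compound 4 `CCOC(=O)c1cnc(N2CCN(Cc3ccc(C(N)=O)cc3)CC2)nc1Oc1c(C)cc(-c2ccc(C#N)cc2)cc1C` differs from compound 3 by 4-carbamoylphenyl in place of 2-fluorophenyl on a saturated chain carbon bound to an amine nitrogen in a ring. The steps a step that the two limits leave unreadable from compound 1 to compound 2, a step that the two limits leave unreadable from compound 1 to compound 3 and a step that the two limits leave unreadable from compound 2 to compound 3 all change the same position, yet none has a readable size, so they give no direction for this change. Compound 4 is therefore expected to reach the limit again, with an expected step of a number no higher from compound 3 to compound 4 (the limit leaves the size open) in this assay. The estimate for compound 4 is 125000 nM, expected between 60000 nM and 250000 nM.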

Compound 4, half-maximal cytotoxic concentration: 66500 nM
Beside the measured number, compound 4's estimate is 1.9-fold (0.27 log units) above it; the range from low to high includes it.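

Within the data shown here, with 4-carbamoylphenyl at this position, compound 4 is the first of the series to give a number rather than a limit in this assay. The result reads as an at least 1.8-fold lower number from compound 3 to compound 4 (0.27 log units; that floor lies within the scatter), as an at least 1.7-fold lower number from compound 2 to compound 4 (0.24 log units; that floor lies within the scatter) and as an at least 1.8-fold lower number from compound 1 to compound 4 (0.27 log units; that floor lies within the scatter), so the change now has a direction, though each step is only a floor. The steps among compounds 1, 2 and 3 still cannot be read.

From the compounds shown here alone, it remains open how large these steps truly are. Going by these compounds, it is also open whether a carboxylic acid or an amine in place of the carbamoyl group would give a number in this assay.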